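Swapping the selenium-bearing ester chain of compound 1

The compounds below may be only part of what the source reports. "The series", "measured", "known", "first", "only" and "open" are said of these compounds alone.

For the measured compounds named here, in a functional assay on HCT-116 cells (Homo sapiens) for inhibition, read by MTT assay, with a stated time of 48 h (a lower number here means a stronger inhibitor, a higher number a weaker inhibitor), compound 1 (`COc1ccc(N(C)c2nc(C)nc3ccccc23)cc1C(=O)OCCCC[Se]C#N`) gives 662 nM, the second highest of the three numbers measured so far. Compound 3 (`COc1ccc(N(C)c2nc(C)nc3ccccc23)cc1C(=O)OCCCCCC[Se]C#N`) lies nearest at 1990 nM, and compound 2 (`Cc1nc(N(C)c2ccc([Se]C#N)c(F)c2)c2ccccc2n1`) lies furthest at 20 nM.

Compound 4 (`COc1ccc(N(C)c2nc(C)nc3ccccc23)cc1OCCN`) has not yet been measured. Its change from compound 1 is a group of 4 heavy atoms (2 carbon, 1 nitrogen, 1 oxygen; no ring) in place of a group of 10 heavy atoms (6 carbon, 1 nitrogen, 2 oxygen, 1 selenium; no ring), on an aromatic carbon: 2-aminoethoxy enters, ortho to a methoxy group and meta to a large group.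

Going by the values given here, only one measured step bears directly on this change: a 3.0-fold higher number from compound 1 to compound 3 (0.48 log units; beyond the scatter). There the larger group goes with the higher number, which weakly suggests that a smaller group could give a lower one. Among the compounds with values here, that single step keeps the selenium, however, and no measured compound lacks it, so the effect of removing it is unknown. Compound 2, at 20 nM, shows that low numbers occur in this set, but it differs from compound 1 in more than one place and is only a loose guide.

A modest move to a lower number is expected, as a 2.2-fold lower number from compound 1 to compound 4 (0.34 log units; beyond the scatter), and the opposite direction is not excluded. The estimate for compound 4 is 300 nM, with an expected range of 50 nM to 1800 nM.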

Compound 4, half-maximal inhibitory concentration: 198 nM
The estimate for compound 4 lay 1.5-fold (0.18 log units) above the measured number; the measured number falls inside the stated range.
By their numbers in this assay, from the lowest: compound 2; then compound 4; then compound 1; then compound 3.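

In this assay, the step of a 3.3-fold lower number from compound 1 to compound 4 (0.52 log units; beyond the scatter) shows that the whole selenium-bearing ester chain can leave this aromatic carbon, with 2-aminoethoxy entering in its place, and the number still falls, so among the compounds with this methoxy-bearing ring, the lowest number now belongs to one without selenium. Its direction agrees with a 3.0-fold higher number from compound 1 to compound 3 (0.48 log units; beyond the scatter), where the larger group also goes with the higher number, and among compounds 1, 3 and 4 none goes against this link between group size and number, though these two steps alone cannot establish a general trend. No available evidence accounts for the drop at this position.

The step changes the ester, the chain length, the selenium and the terminal amine at once, so the compounds shown cannot assign the drop to any one of these. As far as these compounds go, a butyl ester without selenium, a longer aminoalkoxy chain or a 2-hydroxyethoxy group at this aromatic carbon would separate these contributions, and how any of them would read in this assay remains open.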